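A Repeated Amine Change Carried Onto a Second Core

This account rests on a few compounds, and the source may have more. Where it says the series, first, only, none or still open, it means among the compounds named here.

Compound 1 `CN(C)Cc1cccc(COc2ccc3ccc(=O)oc3c2)c1` and compound 3 `CN(C)Cc1ccc(COc2ccc3ccc(=O)oc3c2)cc1` are built from the same atoms joined differently; the difference between the two cores is not broken down here. In an assay for inhibition of Amine oxidase [flavin-containing] B (Rattus norvegicus), read by spectrophotometry (on this read-out lower numbers stand for stronger inhibition and higher numbers for weaker inhibition), compound 1 gives 3200 nM, and compound 3 gives 3700 nM. Compound 2 `CN(Cc1cccc(C#N)c1)Cc1cccc(COc2ccc3ccc(=O)oc3c2)c1` differs from compound 1 by one change, (3-cyanophenyl in place of hydrogen on a saturated chain carbon bound to an amine nitrogen), and in this assay compound 2 gives 3700 nM; the step of a 1.2-fold higher number from compound 1 to compound 2 (0.06 log units; within the scatter) lies within the scatter, so the two readings are treated as level. Compound 4 `CN(Cc1ccc(COc2ccc3ccc(=O)oc3c2)cc1)Cc1cccc(C#N)c1` carries the same change onto the core of compound 3, (3-cyanophenyl in place of hydrogen on a saturated chain carbon bound to an amine nitrogen), at the same place, and it is the only other occurrence of this change among the four compounds. Compound 4 has not yet been measured in this assay. Going by the values given here, because the one measured instance of the change gave a 1.2-fold higher number from compound 1 to compound 2 (0.06 log units; within the scatter), compound 4 is expected to land close to compound 3. Compound 4 is therefore estimated at about 4300 nM, with a likely range from 2000 nM to 9500 nM. That estimate means an expected step of a 1.2-fold higher number from compound 3 to compound 4 (0.07 log units; within the scatter), sitting beside the earlier one.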

Compound 4, half-maximal inhibitory concentration: 2800 nM
The estimate for compound 4 lay 1.5-fold (0.19 log units) above the measured number; the range from low to high includes it.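

In this assay, the change gives a 1.3-fold lower number from compound 3 to compound 4 (0.12 log units; within the scatter), so the readings for this pair are treated as level, as they were on the core of compound 1. Going by these compounds alone, the two instances of the change do not differ from each other: the same change on two cores in this assay, a 1.2-fold higher number (0.06 log units; within the scatter) from compound 1 to compound 2 and a 1.3-fold lower number (0.12 log units; within the scatter) from compound 3 to compound 4, 1.5-fold (0.18 log units) apart, within the scatter of two such steps Across these two cores, then, replacing methyl with 3-cyanobenzyl leaves the reading level both times, but this rests on only two pairs and does not show that the change would behave the same way on any other core. Nor does a pair of steps this small show how the two cores would compare under a change that moved the reading beyond the scatter.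

The compounds shown leave open whether a plain benzyl group, which lacks the nitrile, would also leave the reading level on either core. They also leave open whether a cyclic amine such as piperidine or a longer chain on the amine nitrogen would shift the reading beyond the scatter.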